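Swapping a butyl chain for a bromophenyl on the amine

A few compounds are considered here, and "the series" means these few. Any claim that something is new, unique, unknown or untested is made for them only; others in the source may bear on it.

Measured compounds:
- compound 1, `CCCc1nn(C)c2c(NCc3ccc(F)cc3)nc(/C=C/c3ccc[n+]([O-])c3)nc12`: < 40000 nM
- compound 2, `CCCCNc1nc(/C=C/c2ccccc2)nc2ccsc12`: > 1000000 nM

Of the compounds shown here, two have been tested in a functional assay on L02 cells (Homo sapiens) for inhibition, read by Griess assay, with stated times of 1 h and 24 h; a higher number here means a weaker inhibitor, a lower number a stronger inhibitor. Compound 1, `CCCc1nn(C)c2c(NCc3ccc(F)cc3)nc(/C=C/c3ccc[n+]([O-])c3)nc12`, gives a value that is only a limit of this assay, < 40000 nM. Compound 2, `CCCCNc1nc(/C=C/c2ccccc2)nc2ccsc12`, likewise gives only a limit in this assay, > 1000000 nM. Among the measured compounds shown here, the two differ in several places at once, so no single step between them can be read off; all that can be said is that compound 2 sits at the limit of > 1000000 nM in this assay, at which 1 of the 2 values shown sits, while compound 1 sits at the limit of < 40000 nM in this assay, at which 1 of the 2 values shown sits.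

Compound 3, `Brc1cccc(Nc2nc(/C=C/c3ccccc3)nc3ccsc23)c1`, is compound 2 with one change: 3-bromophenyl in place of butyl on a nitrogen on an aromatic ring, that is, butylamino becomes (3-bromophenyl)amino. For the measured compounds named here, no measured step of this kind exists in this set, so the size and direction of the change in this assay are open. Given that compound 2 shows only a limit, > 1000000 nM, compound 3 is expected to remain weak, and the estimated step of an at least 2.0-fold lower number from compound 2 to compound 3 (0.30 log units; that floor lies within the scatter) is taken as small. The estimate for compound 3 is 500000 nM, with a range from 50000 nM to 2000000 nM.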

Compound 3, half-maximal inhibitory concentration: > 1000000 nM
Compound 3: no number, only a limit; the forecaster's own chance of this, stated with the estimate: 65%; middle value at least 2.0-fold (0.30 log units) away from the limit.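

In this assay compound 3 gives > 1000000 nM, which is a limit of the assay. Compound 2 gives > 1000000 nM, also a limit, so no step can be read between compound 2 and compound 3. As far as these compounds go, whether 3-bromophenyl in place of butyl changes the inhibition at all, in which direction and by how much, stays open.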